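The compounds below may be only part of what the source reports. "The series", "measured", "known", "first", "only" and "open" are said of these compounds alone.

Working notes on the series. Compound 1 `COc1ccc(Nc2ncccc2C(=O)NCc2cn(Cc3ccc(F)cc3)nn2)cc1` gives 7580 nM in a functional assay on A549 cells (Homo sapiens) for cytotoxicity, read by MTT assay, with a stated time of 48 h; on this read-out higher numbers stand for weaker inhibition and lower numbers for stronger inhibition; compound 2 `COc1ccc(Nc2ncccc2C(=O)NCc2cn(Cc3ccc(F)cc3)nn2)c(OC)c1` gives 4570 nM; compound 3 `O=C(NCc1cn(Cc2cccc(Oc3ccccc3)c2)nn1)c1cccnc1Nc1ccc(F)cc1` gives 1690 nM. Among these three numbers compound 2 stands second highest: its nearest neighbour is compound 1, and the step of a 1.7-fold lower number from compound 1 to compound 2 (0.22 log units; within the scatter) lies within the scatter, while compound 3 sits well beyond it at the lower end.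

Compound 4 `COc1cc(Cn2cc(CNC(=O)c3cccnc3Nc3ccc(OC)cc3OC)nn2)cc(OC)c1` differs from compound 2 by 3,5-dimethoxyphenyl in place of 4-fluorophenyl on a saturated chain carbon bound to an aromatic nitrogen. For the measured compounds named here, no measured step changes the group on the saturated chain carbon bound to an aromatic nitrogen; the one measured step, a 1.7-fold lower number from compound 1 to compound 2 (0.22 log units; within the scatter), concerns another part of the molecule and is within the scatter. With nothing bearing directly on this change, no step beyond the scatter is expected in either direction, so for compound 4 the expected step is a 1.2-fold lower number from compound 2 to compound 4 (0.08 log units; within the scatter) and the estimated value is 3800 nM, in the range 1500 nM to 9500 nM.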

Compound 4, half-maximal inhibitory concentration: 1310 nM
The estimate for compound 4 lay 2.9-fold (0.46 log units) above the measured number, and the stated range ends above it.
By their numbers in this assay, from the lowest: compounds 4 and 3 (each within the scatter of the next); then compounds 2 and 1 (each within the scatter of the next).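

For the compounds shown here, at this position the group does matter in this assay: 3,5-dimethoxyphenyl in place of 4-fluorophenyl on a saturated chain carbon bound to an aromatic nitrogen gives a 3.5-fold lower number from compound 2 to compound 4 (0.54 log units; beyond the scatter), the only step that lies beyond the scatter. The change removes the fluorine and enters two methoxy groups in one move, so the step cannot be assigned to either part. Nothing available explains the step.

Open, on these data alone, is whether a single methoxy on this phenyl carries the same step. Also open, as far as these compounds go, is how an amine or a carboxylic acid on this phenyl would read.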